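A few compounds are considered here, and "the series" means these few. Any claim that something is new, unique, unknown or untested is made for them only; others in the source may bear on it.

Measured so far in a functional assay on HeLa cells (Homo sapiens) for antiproliferative activity, read by sulforhodamine B assay, with a stated time of 72 h; on this read-out lower numbers stand for stronger inhibition and higher numbers for weaker inhibition:

- compound 1 `Cc1ccc(C(/C=C/c2ccc(F)cc2)=N\Nc2nncc3ccccc23)cc1`: 3.4 nM
- compound 2 `NC(=S)NNc1nncc2ccccc12`: 37 nM
- compound 3 `O=S(=O)(Nc1ccccn1)c1ccc(Nc2nncc3ccccc23)cc1`: 26 nM

Compound 3 has the second highest of the three numbers. Its nearest neighbour is compound 2, whose number is only slightly higher, so the two cannot be told apart within the usual scatter. Compound 1 stands furthest away, with a number low enough that the gap to compound 3 is beyond the scatter. Compound 3 and compound 4 `O=S(=O)(Nc1ncccn1)c1ccc(Nc2nncc3ccccc23)cc1` share the same core and differ in one place: pyrimidin-2-yl in place of pyridin-2-yl on a sulfonamide nitrogen. Within the data shown here, no measured pair shows this exact exchange, so no step can be borrowed from the data. The change keeps the ring size and replaces one aromatic carbon with a nitrogen; the expected step in this assay from compound 3 to compound 4 is small, with no clear direction, and most likely within the scatter. The estimated step is a 1.2-fold higher number from compound 3 to compound 4 (0.06 log units; within the scatter). Compound 4 is therefore expected to give 30 nM, within a range from 10 nM to 90 nM.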

Compound 4, half-maximal inhibitory concentration: 14 nM
Estimate against measurement, compound 4: 2.1-fold (0.33 log units) above, and the stated range covers the measured number.
By their numbers in this assay, from the lowest: compound 1; then compounds 4, 3 and 2 (each within the scatter of the next, the first and the last beyond it).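

Among these compounds, this is the first view of the group on the sulfonamide nitrogen. In this assay, pyrimidin-2-yl in place of pyridin-2-yl gives a 1.9-fold lower number from compound 3 to compound 4 (0.27 log units; within the scatter) and so the two compounds cannot be told apart. At this place, then, a six-membered aromatic ring with 2 hetero atoms and one with 1 hetero atom give numbers that lie within the usual spread of repeat measurements, and nothing available bears on why.

Both groups are six-membered aromatic rings containing nitrogen, so the compounds shown leave open what a ring without nitrogen, such as phenyl, would give on the sulfonamide nitrogen. On these data alone, a small chain such as methyl, or a plain hydrogen on that nitrogen, is equally open.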